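A few compounds are considered here, and "the series" means these few. Any claim that something is new, unique, unknown or untested is made for them only; others in the source may bear on it.

Measured so far, in an ADME assay on microsomes from liver (Mus musculus) for metabolic stability, read by LC-MS, with a stated time of 30 min, tested at 1 uM; a higher number here means that more of the compound is left, a lower number that less of the compound is left:

compound 1 `O=C(NCc1ccc(S(=O)(=O)c2ccccc2)cc1)c1cc2ncccc2s1` gives 1.6%
compound 2 `O=C(NCc1ccc(S(=O)(=O)N2CCCCC2)cc1)c1ccn2cncc2c1` gives 1%
compound 3 `O=C(NCc1ccc(S(=O)(=O)c2cccc(C(F)(F)F)c2)cc1)c1cc2cnccc2[nH]1` gives 49%

Compound 2 stands at the lowest of these three numbers. Its nearest neighbour is compound 1, and the gap between them lies within the usual scatter, so no order between the two can be claimed. Compound 3 sits far higher, and that gap lies beyond the scatter.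

Compound 4 `O=C(NCc1ccc(S(=O)(=O)N2CCCCC2)cc1)c1cc2cccnc2s1` is compared with compound 2. The change sits on the carbonyl carbon: a group of 9 heavy atoms (7 carbon, 1 nitrogen, 1 sulfur; one five-membered aromatic ring with 1 hetero atom, one six-membered aromatic ring with 1 hetero atom) in place of a group of 9 heavy atoms (7 carbon, 2 nitrogen; one five-membered aromatic ring with 2 hetero atoms, one six-membered aromatic ring with 1 hetero atom), on a carbonyl carbon.

No step between measured compounds is known for this change, so its size must be judged from what is shown. Compound 1 also carries, on its carbonyl carbon, a group with one sulfur in a five-membered aromatic ring joined to a six-membered aromatic ring with one nitrogen, and in this assay compound 1 gives 1.6%, a low number. I therefore expect the step of a number 4 percentage points higher from compound 2 to compound 4 (within the scatter) to be small, upward if anything, and probably within the scatter. Compound 4 is estimated at 5%, most likely between 1% and 25%.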

Compound 4, percent of the compound remaining: "below limit of detection" (no number reported)
No number was reported for compound 4, and the estimate cannot be compared.
By their numbers in this assay, from the lowest: compounds 2 and 1 (each within the scatter of the next); then compound 3.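

In this assay, among these compounds, compound 4 is reported as below the limit of detection, without a number, so no step from compound 2 can be read. The compounds shown leave open how far this change on the carbonyl carbon moves the read-out. No measurement shown here offers an explanation for this result.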